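From methyl to phenyl on compound 3

The source may hold more compounds than are shown below. What is called first, only, known or untested is meant among the compounds shown, and "the series" means these compounds.

Measured in a functional assay on NCI-H2122 cells (Homo sapiens) for inhibition, read by microscopy, with a stated time of 10 days; on this read-out higher numbers stand for weaker inhibition and lower numbers for stronger inhibition:
- Compound 1 `Cn1nc(-c2ccccc2)c2c1OC(N)=C(C#N)C2c1ccccc1` gives > 10000 nM, a limit
- Compound 2 `COc1ccc(C2C(C#N)=C(N)Oc3c2c(-c2ccccc2)nn3C)cc1` gives > 10000 nM, a limit
- Compound 3 `Cc1nn(C)c2c1C(c1ccc(C(F)(F)F)cc1)C(C#N)=C(N)O2` gives 2200 nM

Among the compounds with values here, compound 3 holds the only true number in this assay, since the other two values are limits. Compound 4 `Cn1nc(-c2ccccc2)c2c1OC(N)=C(C#N)C2c1ccc(C(F)(F)F)cc1` keeps the rest of compound 3 but carries phenyl in place of methyl on an aromatic carbon.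

Within the data shown here, the only measured step, a step that the two limits leave unreadable from compound 1 to compound 2, is a different change and gives no size. Compound 1 and compound 2 both carry phenyl at this place, and both sit at the limit of > 10000 nM in this assay, at which 2 of the 3 values shown sit. Weaker inhibition is therefore expected, with a 2.7-fold higher number from compound 3 to compound 4 (0.44 log units; beyond the scatter) as the estimated step, and the assay may report only a limit. For compound 4 the expected value is 6000 nM, within 2000 nM to 20000 nM.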

Compound 4, half-maximal inhibitory concentration: 4100 nM
Compound 4: the middle estimate sits 1.5-fold (0.17 log units) above what was measured; the range from low to high includes it.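

In this assay, phenyl in place of methyl gives a 1.9-fold higher number from compound 3 to compound 4 (0.27 log units; within the scatter) and so this place takes phenyl with no change beyond the scatter. Trifluoromethyl in place of methoxy gives an at least 2.4-fold lower number from compound 2 to compound 4 (0.38 log units; beyond the scatter) and trifluoromethyl in place of hydrogen gives an at least 2.4-fold lower number from compound 1 to compound 4 (0.38 log units; beyond the scatter) with phenyl kept, so phenyl alone does not set the outcome in this set. Both of these steps start from a limit: the limit of > 10000 nM in this assay, at which 2 of the 4 values shown sit.

From the compounds shown here alone, whether an amine or a longer chain at this place would keep the inhibition stays open. So does the effect of a carboxylic acid in place of trifluoromethyl.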